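The compounds below may be only part of what the source reports. "The series", "measured", "known", "first", "only" and "open" are said of these compounds alone.

For the measured compounds named here, compound 1, `CC(CCNC(=O)c1c(Cl)cncc1Cl)N1CCC(C(Oc2cccc(F)c2)c2ccc(C(F)(F)F)cc2)CC1`, is one of two compounds measured in an ADME assay on PBMC cells (Homo sapiens) for cytotoxicity (a higher number here means that more compound is tolerated, a lower number that less compound is tolerated), and its result is the only one given as a number: in this assay compound 1 gives 5400 nM. Compound 2, `CC(CCNC(=O)c1c(Cl)cncc1Cl)N1CCC(C(Oc2cccc(Cl)n2)c2ccc(S(C)(=O)=O)cc2)CC1`, reaches only a limit of the assay, where in this assay compound 2 gives > 29500 nM. This is recorded as the limit of > 29500 nM in this assay, at which 1 of the 2 values shown sits. Compound 3, `CC(CCNC(=O)c1c(Cl)cncc1Cl)N1CCC(C(Oc2ccccc2C#N)c2ccc(C(F)(F)F)cc2)CC1`, has not yet been measured; it differs from compound 1 in one place: 2-cyanophenyl in place of 3-fluorophenyl on an oxygen on a saturated carbon. Going by the values given here, no measured step between compounds that differ in only one place exists here, so the size of the step has to be estimated from the structures alone. He expects the step of a 1.1-fold higher number from compound 1 to compound 3 (0.05 log units; within the scatter) to stay within the scatter of repeated measurements, with no clear direction. For compound 3 he therefore expects a value near 6000 nM, with a range from 2500 nM to 15000 nM.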

Compound 3, half-maximal cytotoxic concentration: 17000 nM
For compound 3 the middle estimate is 2.8-fold (0.45 log units) below the measured one, outside the stated range (above it).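

In this assay, replacing 3-fluorophenyl with 2-cyanophenyl on the oxygen gives a 3.1-fold higher number from compound 1 to compound 3 (0.50 log units; beyond the scatter). For the compounds shown here, this shows that the result responds to this one group while the rest of compound 1 stays the same, and it is the first step available between compounds that differ in only one place. As a single modest step, it gives the size of this one exchange and no trend, and nothing shown here accounts for its cause.

The compounds shown leave open whether the step follows the nitrile itself or its place on the ring, a question that 3-cyanophenyl and 2-fluorophenyl would separate. Also open, going by these compounds, is how this assay would respond to an amine or a carboxylic acid on the same ring.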